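The source may hold more compounds than are shown below. What is called first, only, known or untested is meant among the compounds shown, and "the series" means these compounds.

Measured compounds in this series:

Compound 1 `Fc1cccc(F)c1C#Cc1ccc2[nH]ccc2c1`: 91.5%
Compound 2 `Cn1ccc2cc(C#Cc3c(F)cccc3F)ccc21`: 95.2%
Compound 3 `Fc1cccc(F)c1C#Cc1ccc2cn[nH]c2c1`: 97%

All three were run in a functional assay on LS174T cells (Homo sapiens) for inhibition, with a stated time of 4 days, tested at 10 uM; on this read-out higher numbers stand for a stronger effect at the one concentration tested and lower numbers for a weaker effect. The only change made twice among these compounds is methyl in place of hydrogen on an aromatic nitrogen, and between the two measured compounds it gave a number 3.7 percentage points higher from compound 1 to compound 2 (within the scatter). Compound 3 carries a different core from compound 1; the difference between the two cores is not broken down here. Compound 2 and compound 3 give numbers within the usual scatter of each other, so no order between them is claimed, and compound 1 also stands within the scatter of compound 3.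

Compound 4 `Cn1ncc2ccc(C#Cc3c(F)cccc3F)cc21` has not been measured in this assay. It differs from compound 3 by methyl in place of hydrogen on an aromatic nitrogen. The surroundings of the change are not the same word for word: in compound 1 the methyl enters on an aromatic nitrogen of a five-membered aromatic ring with 1 nitrogen, whereas in compound 3 it enters on an aromatic nitrogen of a five-membered aromatic ring with 2 nitrogen, next to the ring nitrogen. It is therefore the same kind of change, not the same change.

The step from compound 3 to compound 4 is expected to be a number 1 percentage points lower from compound 3 to compound 4 (within the scatter), about as flat as the earlier methyl step, because compound 3 already gives 97% and the read-out has little room left above it. For compound 4 the estimate in this assay is 96%, from 88% to 100%.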

Compound 4, a percentage reported as inhibition, at one concentration (the size of the read-out at that concentration, not a potency): 98.1%
Compound 4: middle estimate off by 2.1 percentage points, on the low side; the measured number falls inside the stated range.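

In this assay, methyl in place of hydrogen on an aromatic nitrogen gives a number 1.1 percentage points higher from compound 3 to compound 4 (within the scatter), and the comparison with the earlier step reads: the same change on two cores in this assay, a number 3.7 percentage points higher (within the scatter) from compound 1 to compound 2 and a number 1.1 percentage points higher (within the scatter) from compound 3 to compound 4, 2.6 percentage points apart, within the scatter of two such steps

On these two cores, then, the change can be carried across without any difference between the steps that stands clear of the scatter, even though the nitrogen that takes the methyl sits in a different five-membered ring in each case. This does not show that the methyl has an effect of its own on either core, nor that the change would behave alike on a third core, and a read-out at one concentration gives only the size of the effect at that concentration, so a stronger or weaker effect of one compound of either pair at other concentrations remains possible.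

Open, as far as these compounds go, is whether a larger group on the same aromatic nitrogen, such as an ethyl group or a longer chain ending in an amine or a carboxylic acid, would leave the read-out where the methyl leaves it. Also open, from the compounds shown here alone, is whether the two methyl steps would still match on a full concentration series, where the read-out is not confined to one tested concentration.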